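Homologating the ester chain in a glycosylated series

This account rests on a few compounds, and the source may have more. Where it says the series, first, only, none or still open, it means among the compounds named here.

Compound 1 `C/C=C1/[C@H](O[C@@H]2O[C@H](CO)[C@@H](O)[C@H](O)[C@H]2O)OC=C(C(=O)OC)[C@H]1CC(=O)OC` and compound 2 `C/C=C1/[C@H](O[C@@H]2O[C@H](CO)[C@@H](O)[C@H](O)[C@H]2O)OC=C(C(=O)OC)[C@H]1CC(=O)OCC` share one core. In a functional assay on SK-BR-3 cells (Homo sapiens) for antiproliferative activity, read by MTT assay, with a stated time of 72 h (a higher number here means a weaker inhibitor, a lower number a stronger inhibitor), compound 1 returns only a limit, > 15000 nM. Compound 2 likewise returns only a limit, > 15000 nM. The change between them is methyl in place of hydrogen on a saturated chain carbon bound to an oxygen next to a carbonyl group, and its step, a step that the two limits leave unreadable from compound 1 to compound 2, cannot be read because both values sit at the limit of > 15000 nM in this assay, at which 2 of the 3 values shown sit. Among the compounds with values here, compound 3 `C/C=C1/[C@H](O[C@@H]2O[C@H](COC(C)=O)[C@@H](OC(C)=O)[C@H](OC(C)=O)[C@H]2OC(C)=O)OC=C(C(=O)OC)[C@H]1CC(=O)OCCC` gives the single number of the set, 6600 nM; how its core differs from that of compound 1 is not broken down here. Compound 4 `C/C=C1/[C@H](O[C@@H]2O[C@H](COC(C)=O)[C@@H](OC(C)=O)[C@H](OC(C)=O)[C@H]2OC(C)=O)OC=C(C(=O)OC)[C@H]1CC(=O)OCCCC` is the same kind of change made on compound 3, (methyl in place of hydrogen on a saturated chain carbon, three bonds along the chain from an oxygen next to a carbonyl group), though here the place is three bonds along the chain from an oxygen next to a carbonyl group rather than bound to it. With the earlier step unreadable, compound 4 is expected to stay close to compound 3, a step of about a 1.3-fold lower number from compound 3 to compound 4 (0.12 log units; within the scatter). Compound 4 is therefore estimated at 5000 nM, within 2000 nM to 15000 nM.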

Compound 4, half-maximal inhibitory concentration: > 15000 nM
Compound 4 ended at the assay's limit; the forecaster's own chance of this, stated with the estimate: 25%; middle value at least 3.0-fold (0.47 log units) from the limit.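

In this assay, the change from propyl to butyl gives an at least 2.2-fold higher number from compound 3 to compound 4 (0.35 log units; beyond the scatter), so on this core the added methyl weakens the antiproliferative effect by at least that much. Compound 4 returns only a limit, > 15000 nM. The same kind of change on the core of compound 1, one bond nearer the ester oxygen, cannot be read, so the compounds shown do not tell whether the step carries from one core to the other: the limit of > 15000 nM in this assay, at which 3 of the 4 values shown sit.

On these data alone, it remains open how an ethyl ester on the core of compound 3 would read in this assay. Also open, as far as these compounds go, is how a pentyl ester or a carboxylic acid would read on either core.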